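The source may report more compounds than this note shows. Statements on the series, on what has been measured and on what is new or still open speak of the compounds shown alone.

Going by the values given here, compound 3 `O=C(CSc1nnc(-c2ccncc2)n1-c1ccccc1)N/N=C/c1cccc(F)c1` is the one member of this small set without a measured number: in a functional assay on HCT-116 cells (Homo sapiens) for inhibition, read by MTT assay, with a stated time of 48 h (a lower number here means a stronger inhibitor, a higher number a weaker inhibitor), compound 3 gives > 50000 nM, which is a limit of the assay rather than a value. Compound 1 `O=C(CSc1nnc(-c2ccncc2)n1-c1ccccc1)N/N=C/c1ccccc1` gives 14700 nM in this assay, and compound 2 `O=C(CSc1nnc(-c2ccncc2)n1-c1ccccc1)N/N=C/c1ccc(F)cc1` gives 7040 nM. The two fluoro compounds part ways around compound 1: a 2.1-fold lower number from compound 1 to compound 2 (0.32 log units; beyond the scatter), whereas an at least 3.4-fold higher number from compound 1 to compound 3 (0.53 log units; beyond the scatter), and an at least 7.1-fold higher number from compound 2 to compound 3 (0.85 log units; beyond the scatter).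

Compound 4 `O=C(CSc1nnc(-c2ccncc2)n1-c1ccccc1)N/N=C/C=C/c1ccccc1` differs from compound 3 by 2-phenylethenyl in place of 3-fluorophenyl on a carbon with a double bond to nitrogen. Among the compounds with values here, none of the measured steps exchanges the whole ring at this place for a 2-phenylethenyl group, so no step bears on the change directly, and the only point of comparison is compound 1, which carries no fluoro on that ring. Because compound 3 sits at a limit, the step from it cannot be sized from the data. Guided by compound 1 and its value of 14700 nM, compound 4 is estimated at 15000 nM, with a range from 4000 nM to 60000 nM. Against the limit of compound 3, this expectation for compound 4 corresponds to an at least 3.3-fold lower number from compound 3 to compound 4 (0.52 log units; beyond the scatter).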

Compound 4, half-maximal inhibitory concentration: 6150 nM
Beside the measured number, compound 4's estimate is 2.4-fold (0.39 log units) above it; the range from low to high includes it.
By their numbers in this assay, from the lowest: compounds 4 and 2 (each within the scatter of the next); then compound 1. At a limit, above all of these: compound 3.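

In this assay, 2-phenylethenyl in place of phenyl gives a 2.4-fold lower number from compound 1 to compound 4 (0.38 log units; beyond the scatter), so at this place on a carbon with a double bond to nitrogen, a group without fluoro can also lower the number. Against 4-fluorophenyl the change gives a 1.1-fold lower number from compound 2 to compound 4 (0.06 log units; within the scatter), which shows that two quite different groups can serve here and that this place is not tied to a fluorophenyl ring. Against 3-fluorophenyl it gives an at least 8.1-fold lower number from compound 3 to compound 4 (0.91 log units; beyond the scatter), a size that rests on a limit and not on a number: the limit of > 50000 nM in this assay, at which 1 of the 4 values shown sits.

The compounds shown leave open whether fluoro on the ring of 2-phenylethenyl would move the number up or down, as it does on the phenyl ring of compound 2 and compound 3. They also do not tell how an amine or a carboxylic acid on that ring would behave.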